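A Methyl on the Anilino Ring of Compound 3

A few compounds are considered here, and "the series" means these few. Any claim that something is new, unique, unknown or untested is made for them only; others in the source may bear on it.

Compound 3 `Cc1nc(Nc2ccccc2)sc1C(=O)/C=C/c1ccccc1Cl` is one of three compounds tested in a functional assay on PC-3 cells (Homo sapiens) for cytotoxicity, read by MTT assay; a higher number here means a weaker inhibitor, a lower number a stronger inhibitor. For compound 3 the assay reports only a limit, > 25000 nM. Compound 1 `Cc1ccccc1Nc1nc(C)c(C(=O)/C=C/c2ccc(Cl)cc2)s1` likewise gives only a limit, > 25000 nM. Compound 2 `COc1cccc(/C=C/C(=O)c2sc(Nc3ccccc3C)nc2C)c1` also gives only a limit, > 25000 nM. For the measured compounds named here, the step from compound 1 to compound 2, a step that the two limits leave unreadable from compound 1 to compound 2, cannot be read, and no pair here yields a readable step since (the limit of > 25000 nM in this assay, at which 3 of the 3 values shown sit). Compound 4 `Cc1ccccc1Nc1nc(C)c(C(=O)/C=C/c2ccccc2Cl)s1` differs from compound 3 by methyl in place of hydrogen on an aromatic carbon, giving anilino to (2-methylphenyl)amino. Going by the values given here, no measured step speaks to this change; compound 1, which carries the same (2-methylphenyl)amino group, also sits at the limit. Compound 4 is therefore expected to remain near the limit in this assay, with a step that the limit leaves unreadable from compound 3 to compound 4. The estimate for compound 4 is 30000 nM, within 10000 nM to 100000 nM.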

Compound 4, half-maximal inhibitory concentration: > 25000 nM
Compound 4: no number, only a limit (the forecaster's own chance of this, stated with the estimate: 85%); the middle value does not contradict the limit.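

In this assay compound 4 gives only a limit, > 25000 nM. For the compounds shown here, no step from compound 1, compound 2 or compound 3 to compound 4 can be read. The compounds shown leave open whether any of these changes alters the read-out in this assay: the limit of > 25000 nM in this assay, at which 4 of the 4 values shown sit.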